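Swapping a Benzyl Ester for an Amide on the Side Chain

The source may report more compounds than this note shows. Statements on the series, on what has been measured and on what is new or still open speak of the compounds shown alone.

In a functional assay on HEL cells (Homo sapiens) (a higher number here means that more compound is tolerated, a lower number that less compound is tolerated), compound 3 `Cc1cn([C@@H]2O[C@H](CO[Si](C)(C)C(C)(C)C)[C@@]3(OS(=O)(=O)C=C3NCC(=O)OCc3ccccc3)[C@H]2O[Si](C)(C)C(C)(C)C)c(=O)n(C)c1=O` gives only a limit of the assay, > 200000 nM. Compound 1 `CCOC(=O)CNC(=O)NC1=CS(=O)(=O)O[C@@]12[C@@H](CO[Si](C)(C)C(C)(C)C)O[C@@H](n1cc(C)c(=O)n(C)c1=O)[C@@H]2O[Si](C)(C)C(C)(C)C` gives 13000 nM, and compound 2 `COC(=O)CC(=O)NC1=CS(=O)(=O)O[C@@]12[C@@H](CO[Si](C)(C)C(C)(C)C)O[C@@H](n1cc(C)c(=O)n(C)c1=O)[C@@H]2O[Si](C)(C)C(C)(C)C` gives 29000 nM, so compound 3 stands at the upper end of the numbers shown. Compound 4 `Cc1cn([C@@H]2O[C@H](CO[Si](C)(C)C(C)(C)C)[C@@]3(OS(=O)(=O)C=C3NCCC(N)=O)[C@H]2O[Si](C)(C)C(C)(C)C)c(=O)n(C)c1=O` differs from compound 3 by carbamoylmethyl in place of benzyloxycarbonyl on a saturated chain carbon bound to an amine nitrogen. Among the compounds with values here, the measured steps that bear on this change are an at least 15-fold higher number from compound 1 to compound 3 (1.18 log units; beyond the scatter) and an at least 6.8-fold higher number from compound 2 to compound 3 (0.83 log units; beyond the scatter), both ending at the same limit (the limit of > 200000 nM in this assay, at which 1 of the 3 values shown sits); no measured step alters this part of the chain directly. Because both earlier steps toward compound 3 ran into that limit (the limit of > 200000 nM in this assay, at which 1 of the 3 values shown sits), compound 4 is expected to stay near it, with the step estimated as a number no higher from compound 3 to compound 4 (the limit leaves the size open). Compound 4 is therefore estimated at 200000 nM, ranging from 60000 nM to 600000 nM.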

Compound 4, half-maximal cytotoxic concentration: 14800 nM
Estimate against measurement, compound 4: 14-fold (1.13 log units) above; measured number outside the range, below it.
By their numbers in this assay, from the lowest: compounds 1, 4 and 2 (each within the scatter of the next, the first and the last beyond it). At a limit, above all of these: compound 3.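

In this assay, carbamoylmethyl in place of benzyloxycarbonyl on this saturated chain carbon gives an at least 13-fold lower number from compound 3 to compound 4 (1.13 log units; beyond the scatter), so this end of the chain clearly affects how much compound is tolerated. With a 2.0-fold lower number from compound 2 to compound 4 (0.29 log units; within the scatter) and a 1.1-fold higher number from compound 1 to compound 4 (0.06 log units; within the scatter), both within the scatter, the 2-carbamoylethyl chain gives a number level with the two carbonyl-linked chains.

On these data alone, the true size of the first step stays open, as compound 3 sits at a limit of the assay: the limit of > 200000 nM in this assay, at which 1 of the 4 values shown sits. Also open is whether the benzyl ring or the ester counts more, which a benzyl amide or a carboxylic acid on the same chain could separate.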